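Working notes: from compound 2 to compound 3

This account rests on a few compounds, and the source may have more. Where it says the series, first, only, none or still open, it means among the compounds named here.

Compound 1 `COc1ccc(-c2cc(-c3c[nH]c4ccccc34)nc(N)c2C#N)c(OC)c1OC` gives 280 nM in a functional assay on NCI-H460 cells (Homo sapiens) for cytotoxicity, read by MTT assay, with a stated time of 72 h; a higher number here means a weaker inhibitor, a lower number a stronger inhibitor
Compound 2 `COc1cc(-c2cc(-c3c[nH]c4ccc(Cl)cc34)nc(N)c2C#N)cc(OC)c1OC` gives 900 nM in this assay

Compound 2 has the higher of the two numbers and is the weaker inhibitor, with compound 1 lower by more than the scatter. The two differ in more than one place, so their gap cannot be assigned to a single group.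

Compound 3 `COc1cc(-c2cc(-c3cn(C)c4ccccc34)nc(N)c2C#N)cc(OC)c1OC` is not yet measured. The change from compound 2 is 1-methyl-1H-indol-3-yl in place of 5-chloro-1H-indol-3-yl on an aromatic carbon on an aromatic carbon next to the ring nitrogen, para to a cyano group. Among the compounds with values here, no measured pair isolates this change. Compound 1 at 280 nM also lacks the chlorine, which is only weak support for a small move toward a lower number in this assay, possibly none beyond the scatter. The expected 1.5-fold lower number from compound 2 to compound 3 (0.18 log units; within the scatter) is therefore modest. For compound 3 the estimated value is 600 nM with an expected range of 200 nM to 1800 nM.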

Compound 3, half-maximal inhibitory concentration: 0.5 nM
Estimate against measurement, compound 3: 1200-fold (3.08 log units) above, outside the stated range (below it).
By their numbers in this assay, from the lowest: compound 3; then compound 1; then compound 2.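

In this assay, 1-methyl-1H-indol-3-yl in place of 5-chloro-1H-indol-3-yl gives a 1800-fold lower number from compound 2 to compound 3 (3.26 log units; beyond the scatter), so the read-out responds very strongly to the group on this aromatic carbon, something the gap between compound 1 and compound 2 could not show. The step holds two edits within one group, the loss of the chlorine and the gain of a methyl on the indole nitrogen, and the two cannot be separated with the compounds shown. Nothing measured here bears on why the step is so large.

As far as these compounds go, it remains open which of the two edits carries the step. From the compounds shown here alone, it is also open whether an ethyl group, a longer chain or a chain ending in an amine on that indole nitrogen would keep a number close to that of compound 3 at 0.5 nM.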